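Methylcarbamoyl for methoxy on the ring-nitrogen phenyl

A few compounds are considered here, and "the series" means these few. Any claim that something is new, unique, unknown or untested is made for them only; others in the source may bear on it.

Compound 2 `CCN1C(=O)N(c2cccc(OC)c2)C(=O)N(c2ccccc2)c2cc(C(F)(F)F)ccc21` carries a 3-methoxyphenyl group on an amide-type nitrogen in a ring of the shared core. In an ADME assay on C8166 cells (Homo sapiens) for cytotoxicity (a higher number here means that more compound is tolerated, a lower number that less compound is tolerated), compound 2 gives only a limit, > 20000 nM. Compound 1 `CCN1C(=O)N(c2ccccc2)C(=O)N(c2ccccc2)c2cc(C(F)(F)F)ccc21` likewise gives only a limit in this assay, > 4000 nM. Compound 3 `CCN1C(=O)N(c2ccc(C)cc2)C(=O)N(c2ccccc2)c2cc(C(F)(F)F)ccc21` also reaches only a limit, > 6500 nM. Because (the limit of > 20000 nM in this assay, at which 1 of the 3 values shown sits), the limit of > 4000 nM in this assay, at which 1 of the 3 values shown sits, and the limit of > 6500 nM in this assay, at which 1 of the 3 values shown sits, are all limits, the steps a step that the two limits leave unreadable from compound 1 to compound 2, a step that the two limits leave unreadable from compound 1 to compound 3 and a step that the two limits leave unreadable from compound 2 to compound 3 cannot be sized. Compound 4 `CCN1C(=O)N(c2ccc(C(=O)NC)cc2)C(=O)N(c2ccccc2)c2cc(C(F)(F)F)ccc21` differs from compound 2 in one place: 4-(methylcarbamoyl)phenyl in place of 3-methoxyphenyl on an amide-type nitrogen in a ring. The unreadable step from compound 2 to compound 3 at this position gives no direction, so no step beyond the scatter is expected. Compound 4 is therefore estimated to give 20000 nM in this assay, between 5000 nM and 60000 nM, an expected step of a number no higher from compound 2 to compound 4 (the limit leaves the size open).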

Compound 4, half-maximal cytotoxic concentration: 31000 nM
Beside the measured number, compound 4's estimate is 1.6-fold (0.19 log units) below it; measured number inside the range.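

Among these compounds, no step from compound 1, compound 2 or compound 3 to compound 4 can be read, as those three compounds give only limits. The compounds shown leave open whether, and how far, any of these substitutions shifts the tolerated concentration.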